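Bromo for chloro: notes on compounds 1 to 4

The source may report more compounds than this note shows. Statements on the series, on what has been measured and on what is new or still open speak of the compounds shown alone.

Measured so far:
Compound 1 `COc1ccc(C(=O)/C=C/c2cccc(Br)c2Oc2c([N+](=O)[O-])cc(C(F)(F)F)cc2[N+](=O)[O-])cc1` gives 2.32 ug/mL in a functional assay on MCF7 cells (Homo sapiens) for antiproliferative activity, read by MTT assay, with a stated time of 48 h; on this read-out higher numbers stand for weaker inhibition and lower numbers for stronger inhibition.
Compound 2 `COc1ccc(C(=O)/C=C/c2cccc(Cl)c2Oc2c([N+](=O)[O-])cc(C(F)(F)F)cc2[N+](=O)[O-])cc1` gives 1.83 ug/mL in this assay.
Compound 3 `O=C(/C=C/c1cc(Cl)cc(Cl)c1Oc1c([N+](=O)[O-])cc(C(F)(F)F)cc1[N+](=O)[O-])c1ccc(Cl)cc1` gives 4.54 ug/mL in this assay.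

Compound 1 and compound 2 differ in one place only: bromo in place of chloro on an aromatic carbon. The step in this assay is a 1.3-fold higher number from compound 2 to compound 1 (0.10 log units; within the scatter), so the two values are not separated here. Compound 3 stands on a different core; the difference between the two cores is not broken down here. Its value lies beyond the scatter from compound 2 and within the scatter of compound 1.

Compound 4 `O=C(/C=C/c1cc(Cl)cc(Cl)c1Oc1c([N+](=O)[O-])cc(C(F)(F)F)cc1[N+](=O)[O-])c1ccc(Br)cc1` is the unmeasured member. It differs from compound 3 in one place: bromo in place of chloro on an aromatic carbon. This is the same kind of change as that from compound 2 to compound 1, not the same: in compound 4 the bromo sits para to a large group, whereas in compound 1 it sits ortto a large group and meta to a 2-((4-methoxyphenyl)carbonyl)ethenyl group.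

With one instance of this swap measured, the expected step from compound 3 to compound 4 is a 1.2-fold higher number from compound 3 to compound 4 (0.08 log units; within the scatter), resting on the within-scatter step a 1.3-fold higher number from compound 2 to compound 1 (0.10 log units; within the scatter). Compound 4 is therefore estimated at 5.5 ug/mL in this assay, expected to fall between 2.7 ug/mL and 11 ug/mL.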

Compound 4, half-maximal inhibitory concentration: 2.6 ug/mL
Compound 4: middle estimate off by 2.1-fold (0.33 log units), on the high side; measured number outside the range, below it.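

In this assay bromo in place of chloro on the core of compound 3 gives a 1.7-fold lower number from compound 3 to compound 4 (0.24 log units; within the scatter) and so does not separate the two values. Set beside the earlier instance, the two steps are printed with opposite signs, yet each step and the gap between them stay inside the usual scatter: the same change on two cores in this assay, a 1.3-fold higher number (0.10 log units; within the scatter) from compound 2 to compound 1 and a 1.7-fold lower number (0.24 log units; within the scatter) from compound 3 to compound 4, 2.2-fold (0.35 log units) apart, within the scatter of two such steps. This shows that, in these two pairs, the change leaves the read-out within the scatter on both cores, so the pairs give no sign that the core alters its outcome; it does not show that the step has a fixed size or direction across the series, and two pairs are too few to establish that the change transfers reliably to other cores.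

The compounds shown leave open what other groups would do at the aromatic carbon that carries the bromo in compound 4, such as fluoro, iodo, a nitrile, an amine or a carboxylic acid, and whether any of them would step beyond the scatter. They also leave open what replacing the trifluoromethyl or either nitro group with, for instance, a nitrile or an amide would do to the number in this assay on either core.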